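Removing the Benzyl on the Glycine Nitrogen

The source may hold more compounds than are shown below. What is called first, only, known or untested is meant among the compounds shown, and "the series" means these compounds.

Compound 3 `CCOC(=O)CN(Cc1ccccc1)c1nc(Nc2cccc(OC)c2)ncc1[N+](=O)[O-]` gives 47200 nM in a functional assay on MDA-MB-231 cells (Homo sapiens) for antiproliferative activity, read by MTT assay, with a stated time of 48 h (a higher number here means a weaker inhibitor, a lower number a stronger inhibitor), the second highest of the three numbers; compound 1 `CCOC(=O)CNc1nc(Nc2ccccc2)ncc1[N+](=O)[O-]` gives 54300 nM, within the scatter of it, while compound 2 `CCOC(=O)CNc1nc(NCc2ccccc2)ncc1[N+](=O)[O-]` gives 22300 nM. Compound 4 `CCOC(=O)CNc1nc(Nc2cccc(OC)c2)ncc1[N+](=O)[O-]` differs from compound 3 by hydrogen in place of benzyl on a nitrogen on an aromatic ring. The only measured step, a 2.4-fold lower number from compound 1 to compound 2 (0.39 log units; beyond the scatter), concerns a different nitrogen, so no shown step bears directly on this change. Compound 1, which also carries hydrogen on that nitrogen, sits within the scatter of compound 3, so for compound 4 the expected step of a 1.1-fold higher number from compound 3 to compound 4 (0.03 log units; within the scatter) is none beyond the scatter. Compound 4 is therefore estimated at 50000 nM, with a range from 20000 nM to 120000 nM.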

Compound 4, half-maximal inhibitory concentration: 31300 nM
Beside the measured number, compound 4's estimate is 1.6-fold (0.20 log units) above it; low and high end bracket the measured number.
By their numbers in this assay, from the lowest: compounds 2, 4, 3 and 1 (each within the scatter of the next, the first and the last beyond it).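

In this assay, taking the benzyl off the nitrogen on the aromatic ring gives a 1.5-fold lower number from compound 3 to compound 4 (0.18 log units; within the scatter), so this large group can be lost without a step beyond the scatter. The two other comparisons also stay within it: 3-methoxyphenyl in place of benzyl gives a 1.4-fold higher number from compound 2 to compound 4 (0.15 log units; within the scatter), and methoxy in place of hydrogen gives a 1.7-fold lower number from compound 1 to compound 4 (0.24 log units; within the scatter). No measurement here explains these results. As far as these compounds go, whether methyl or a longer chain on that nitrogen would give a clearer step remains open. So does the effect of a carboxylic acid there.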